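A few compounds are considered here, and "the series" means these few. Any claim that something is new, unique, unknown or untested is made for them only; others in the source may bear on it.

Of the compounds shown here, three built on one shared core have been tested in a functional assay on A549 cells (Homo sapiens) for inhibition, read by MTT assay, with a stated time of 24 h; a higher number here means a weaker inhibitor, a lower number a stronger inhibitor. Compound 1 `COc1ccccc1-n1cc(CN2C(=O)C[C@@H]3CC[C@@]2(C)C3(C)C)nn1` gives 350 nM; compound 2 `COc1ccc(-n2cc(CN3C(=O)C[C@@H]4CC[C@@]3(C)C4(C)C)nn2)cc1` gives 50 nM; compound 3 `CC1(C)[C@H]2CC[C@]1(C)N(Cc1cn(-c3ccccc3)nn1)C(=O)C2` gives 70 nM. Compound 3 stands second highest of the three: its gap to compound 2 lies within the scatter, while a 5.0-fold lower number from compound 1 to compound 3 (0.70 log units; beyond the scatter) lies beyond it. Compound 4 `CC1(C)[C@H]2CC[C@]1(C)N(Cc1cn(-c3cccc(O)c3)nn1)C(=O)C2` differs from compound 3 by hydroxy in place of hydrogen on an aromatic carbon. For the measured compounds named here, no measured step introduces a hydroxy; the nearest guides are a 1.4-fold higher number from compound 2 to compound 3 (0.15 log units; within the scatter) and a 5.0-fold lower number from compound 1 to compound 3 (0.70 log units; beyond the scatter), where an oxygen-bearing group on this ring once stayed within the scatter and once gave a higher number. A small step is therefore expected, a 1.1-fold higher number from compound 3 to compound 4 (0.06 log units; within the scatter), with no firm direction. Compound 4 is estimated at 80 nM, within 30 nM to 250 nM.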

Compound 4, half-maximal inhibitory concentration: 180 nM
Beside the measured number, compound 4's estimate is 2.3-fold (0.35 log units) below it; the measured number falls inside the stated range.
By their numbers in this assay, from the lowest: compounds 2 and 3 (each within the scatter of the next); then compounds 4 and 1 (each within the scatter of the next).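

In this assay, hydroxy on the phenyl ring, meta to a large group, is a change beyond the scatter (a 2.6-fold higher number from compound 3 to compound 4 (0.41 log units; beyond the scatter)), so this position does not tolerate every small oxygen-bearing group equally. The 3-hydroxyphenyl group also separates from 4-methoxyphenyl (a 3.6-fold higher number from compound 2 to compound 4 (0.56 log units; beyond the scatter)) but not from 2-methoxyphenyl (a 1.9-fold lower number from compound 1 to compound 4 (0.29 log units; within the scatter)), a step within the scatter. Nothing measured here explains the shift. The compounds shown leave open how methoxy would behave at this same place, which would separate the group's identity from its position. Going by these compounds, an amine or a carboxylic acid there also remains untested in this set.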